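The compounds below may be only part of what the source reports. "The series", "measured", "known", "first", "only" and "open" are said of these compounds alone.

In a functional assay on cells (Cancer cell lines, Homo sapiens) for inhibition (on this read-out lower numbers stand for stronger inhibition of growth and higher numbers for weaker inhibition of growth), compound 1 `Cc1cc(-c2nc3sc(C)cn3c2/C=N/NC(=N)N)c(C)s1` gives 12000 nM and compound 2 `N=C(N)N/N=C/c1c(-c2cccs2)nc2sccn12` gives 10200 nM. Within the data shown here, these two values lie within the scatter of each other, so compound 2 does not stand apart on the numbers so far. Compound 3 `Cc1cn2c(/C=N/NC(=N)N)c(-c3cccs3)nc2s1` has not yet been measured. It differs from compound 2 in one place: methyl in place of hydrogen on an aromatic carbon, next to the ring sulfur. Among the measured compounds shown here, no step between measured compounds is available to size this change, so the expectation rests only on the two values in hand. No step beyond the scatter is expected in this assay, and neither direction is favoured. The estimated 1.0-fold higher number from compound 2 to compound 3 (0.01 log units; within the scatter) fits that expectation. For compound 3 the expected value is 10500 nM, with an estimated range of 4500 nM to 22000 nM.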

Compound 3, concentration for 50% growth inhibition: 6460 nM
Compound 3: the middle estimate sits 1.6-fold (0.21 log units) above what was measured; the measured number falls inside the stated range.
By their numbers in this assay, from the lowest: compounds 3, 2 and 1 (each within the scatter of the next).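

In this assay, among these compounds, methyl in place of hydrogen on an aromatic carbon, next to the ring sulfur, gives a 1.6-fold lower number from compound 2 to compound 3 (0.20 log units; within the scatter), which is the first sized step at this position. With methyl present at this position in both compounds, thiophen-2-yl in place of 2,5-dimethylthiophen-3-yl on an aromatic carbon gives a 1.9-fold lower number from compound 1 to compound 3 (0.27 log units; within the scatter), so this second change also stays inside the scatter. No supporting measurement is available to explain either step.

As far as these compounds go, it remains open whether any group on this aromatic carbon other than methyl, such as ethyl, methoxy or an amine, would move the number beyond the scatter. From the compounds shown here alone, compound 1, compound 2 and compound 3 share one side chain on the core, so the effect of a carboxylic acid in its place also remains unknown.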